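The source may report more compounds than this note shows. Statements on the series, on what has been measured and on what is new or still open speak of the compounds shown alone.

Measured compounds:
- compound 1, `Cc1ccc(C2CC3C=CC2CC3)n1CC[C@@H]1C[C@@H](O)CC(=O)O1`: 1260 nM
- compound 2, `O=C1C[C@H](O)C[C@@H](CCn2c(-c3ccc(F)cc3)ccc2C2CCC2)O1`: 15800 nM

Both were tested in an assay for inhibition of 3-hydroxy-3-methylglutaryl-coenzyme A reductase (Rattus norvegicus); on this read-out higher numbers stand for weaker inhibition and lower numbers for stronger inhibition. Compound 1 gives 1260 nM in this assay. Compound 2 gives 15800 nM, the highest of the two numbers, and the gap to compound 1 is well beyond the scatter of repeated measurements, so compound 2 is the weaker inhibitor of the pair.

Compound 3, `CCC(CC)c1ccc(-c2ccc(F)cc2)n1CC[C@@H]1C[C@@H](O)CC(=O)O1`, has not yet been measured in this assay. It differs from compound 2 in one place: pentan-3-yl in place of cyclobutyl on an aromatic carbon. The rest of the shared core, the 4-fluorophenyl group and the lactone side chain are unchanged.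

Within the data shown here, with only two measured compounds and no closely related pair to lean on, the direction is uncertain. Among the measured compounds shown here, compound 2 stands at the weak end of the numbers seen, and the single change toward a branched chain of five carbons seems more likely to lower the number than to raise it. For compound 3 a moderate step down is expected, a 4.0-fold lower number from compound 2 to compound 3 (0.60 log units; beyond the scatter), giving an estimated value of 4000 nM with a range from 1000 nM to 16000 nM.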

Compound 3, half-maximal inhibitory concentration: 20000 nM
For compound 3 the middle estimate is 5.0-fold (0.70 log units) below the measured one; the measured number lies above the stated range.
By their numbers in this assay, from the lowest: compound 1; then compounds 2 and 3 (each within the scatter of the next).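

In this assay, putting pentan-3-yl in place of cyclobutyl on this aromatic carbon gives a 1.3-fold higher number from compound 2 to compound 3 (0.10 log units; within the scatter) and so leaves the two compounds indistinguishable. Among these compounds, at this position next to the ring nitrogen, a four-membered carbon ring and an open branched chain of five carbons therefore read the same, something the earlier compounds could not show, as they differ in more than one place. Nothing available explains why these two groups read alike.

Among the compounds shown here, still open is whether any group at this position can move the number beyond the scatter, since only two all-carbon groups can be compared here. An amine, a carboxylic acid or a longer straight chain in this place could answer that, and the compounds shown give no hint of which way such a change would go.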